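This account rests on a few compounds, and the source may have more. Where it says the series, first, only, none or still open, it means among the compounds named here.

Compound 1, `Nc1nc2c(c(-c3ccco3)cn2[C@@H]2O[C@H](CO)[C@@H](O)[C@H]2O)c(=O)[nH]1`: in a functional assay on CEM-DNR-bulk cells (Homo sapiens), read by MTT assay, with a stated time of 72 h (on this read-out higher numbers stand for weaker inhibition and lower numbers for stronger inhibition), compound 1 reaches only the limit of the assay, > 20000 nM.
Compound 2, `Nc1nc2c(c(-c3cc4ccccc4o3)cn2[C@@H]2O[C@H](CO)[C@@H](O)[C@H]2O)c(=O)[nH]1`: in this assay compound 2 likewise stops at the assay limit, > 20000 nM.
Compound 3, `Nc1nc(N)c2c(-c3cc4ccccc4o3)cn([C@@H]3O[C@H](CO)[C@@H](O)[C@H]3O)c2n1`: in this assay compound 3 also gives a limit, > 20000 nM.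

Compound 1 and compound 2 share one core and differ in a single place: furan-2-yl in place of 1-benzofuran-2-yl on an aromatic carbon. The step that the two limits leave unreadable from compound 2 to compound 1 has no readable size because of the limit of > 20000 nM in this assay, at which 3 of the 3 values shown sit, so this pair says nothing about whether the smaller ring helps or harms. Compound 3 carries a different core; the difference between the two cores is not broken down here.

The unmeasured compound is compound 4, `Nc1nc(N)c2c(-c3ccco3)cn([C@@H]3O[C@H](CO)[C@@H](O)[C@H]3O)c2n1`. It stands to compound 3 as compound 1 stands to compound 2: furan-2-yl in place of 1-benzofuran-2-yl on an aromatic carbon. The place described for both changes is the same word for word, so this is the same change made on the other core.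

For compound 4 the step that the limit leaves unreadable from compound 3 to compound 4 is expected to be too small to read, since the measured example of this change sits between two limits. Within the data shown here, this expectation rests on compound 3, which gives > 20000 nM, and on the fact that every value so far sits at the limit of this assay. Compound 4 is therefore estimated at 30000 nM, with a range from 10000 nM to 100000 nM, and most likely a further limit rather than a number.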

Compound 4, half-maximal inhibitory concentration: > 20000 nM
Compound 4: a limit, no number; the forecaster's own chance of this, stated with the estimate: 85%; the middle value is on the limit's open side.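

In this assay compound 4 gives > 20000 nM as a limit and not a number. No step can be read between compound 3 and compound 4, because of one shared fact: the limit of > 20000 nM in this assay, at which 4 of the 4 values shown sit. The compounds shown leave open how strongly any of them inhibits these cells, and whether furan-2-yl or 1-benzofuran-2-yl gives stronger inhibition on either core.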